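This account rests on a few compounds, and the source may have more. Where it says the series, first, only, none or still open, it means among the compounds named here.

In an ADME assay on Vero cells (Chlorocebus sabaeus) for cytotoxicity, read by resazurin assay, with a stated time of 72 h (a lower number here means a stronger inhibitor, a higher number a weaker inhibitor), compound 1 (`Cc1ccc(C(=O)CCN2CCN(c3ccc(C(F)(F)F)cc3)CC2)cc1`) gives 140000 nM while compound 2 (`Cc1ccc(C(=O)CCN2CCN(c3ccc(Cl)cc3)CC2)cc1`) gives 184000 nM and compound 3 (`O=C(CCN1CCN(c2ccc(Cl)cc2)CC1)c1ccc(Cl)c(F)c1`) gives 175000 nM so compound 2 stands within the scatter of both others. Compound 4 (`O=C(CCN1CCN(c2ccc(Cl)cc2)CC1)c1ccc(C(F)(F)F)cc1`) is still unmeasured and carries trifluoromethyl in place of methyl on an aromatic carbon relative to compound 2. For the measured compounds named here, two measured steps bear on this. Chloro in place of trifluoromethyl gave a 1.3-fold higher number from compound 1 to compound 2 (0.12 log units; within the scatter) and 4-chloro-3-fluorophenyl in place of 4-methylphenyl gave a 1.1-fold lower number from compound 2 to compound 3 (0.02 log units; within the scatter) and both are small. No step beyond the scatter is therefore expected in this assay in either direction. The expected change is a 1.2-fold lower number from compound 2 to compound 4 (0.06 log units; within the scatter) and it stays within the scatter. Compound 4 is estimated at 160000 nM with an expected range from 90000 nM to 280000 nM in this measurement.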

Compound 4, half-maximal inhibitory concentration: 54200 nM
Compound 4: middle estimate off by 3.0-fold (0.47 log units), on the high side; the whole stated range lies above it.
By their numbers in this assay, from the lowest: compound 4; then compounds 1, 3 and 2 (each within the scatter of the next).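

In this assay, trifluoromethyl in place of methyl on this aromatic carbon gives a 3.4-fold lower number from compound 2 to compound 4 (0.53 log units; beyond the scatter), the only step shown that lies beyond the scatter, so this position is not silent. The earlier change at this end of the molecule, a 1.1-fold lower number from compound 2 to compound 3 (0.02 log units; within the scatter), stayed within the scatter, so the outcome here depends on which group enters. Nothing shown gives a reason for this step. From the compounds shown here alone, whether a nitrile or a methoxy group on this carbon would shift the number as well remains open.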